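The source may report more compounds than this note shows. Statements on the series, on what has been measured and on what is new or still open speak of the compounds shown alone.

Two compounds share one core, a pyrazole-linked enone chain carrying an aryl ketone, and both have been tested in a functional assay on OVCAR-5 cells (Homo sapiens) for cytotoxicity, read by sulforhodamine B assay, with a stated time of 48 h, tested at 10 uM; a lower number here means a stronger effect, a higher number a weaker effect of the compound at the concentration tested. Compound 1, `COc1ccc(-c2cc(/C=C/C(=O)c3ccc(N)cc3)[nH]n2)cc1`, gives -41% in this assay. Compound 2, `COc1cc(-c2cc(/C=C/C(=O)c3ccc(Cl)c(Cl)c3)[nH]n2)cc(OC)c1OC`, gives 65% in this assay, the highest of the two numbers shown, and stands a long way above compound 1, well beyond the usual scatter. No single-point change links these two, so their values are simply read side by side.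

Compound 3, `COc1ccc(C(=O)/C=C/c2cc(-c3cc(OC)c(OC)c(OC)c3)n[nH]2)cc1`, has not yet been measured. It differs from compound 2 in one place: 4-methoxyphenyl in place of 3,4-dichlorophenyl on a carbonyl carbon. Among the measured compounds shown here, no measured pair shows the effect of this exchange, so the expectation rests only on the spread between compound 1 and compound 2. The step from compound 2 to compound 3 is expected to be a number 35 percentage points lower from compound 2 to compound 3 (beyond the scatter), a fall beyond the scatter. Compound 3 is therefore estimated at 30%, within a range from -20% to 70%.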

Compound 3, a percentage reported as activity, at one concentration (the size of the read-out at that concentration, not a potency): -70%
Beside the measured number, compound 3's estimate is 100 percentage points above it; the measured number lies below the stated range.
By their numbers in this assay, from the lowest: compound 3; then compound 1; then compound 2.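

In this assay, putting 4-methoxyphenyl in place of 3,4-dichlorophenyl on the carbonyl carbon gives a number 135 percentage points lower from compound 2 to compound 3 (beyond the scatter) and so a much stronger effect at the concentration tested. Among the compounds shown here, this is the first direct reading of this position, and it shows that the choice of group here matters greatly, even though both groups are a single six-membered aromatic ring of carbon with the same count of heavy atoms. Nothing measured explains the size of this step.

This single pair cannot separate what the incoming methoxy group contributes from what is changed by removing the two chlorine atoms. A plain phenyl group, or the same ring carrying a hydroxyl group or a longer ether chain such as ethoxy, would help to tell these apart.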